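The compounds below may be only part of what the source reports. "The series", "measured", "known", "first", "only" and "open" are said of these compounds alone.

Compound 3 `CN(Cc1nc2cc(C(F)(F)F)ccc2nc1-c1ccccc1)c1ccc(OC(F)(F)F)cc1` gives 3000 nM in an assay on isolated protein for inhibition of Dihydrofolate reductase (Homo sapiens), read by spectrophotometry; a lower number here means a stronger inhibitor, a higher number a weaker inhibitor. It stands level with compound 2 `COc1ccc(N(C)Cc2nc3cc(C(F)(F)F)ccc3nc2-c2ccccc2)cc1`, which gives 3000 nM, while compound 1 `CN(Cc1nc2cc(C(F)(F)F)ccc2nc1-c1ccccc1)c1ccc(Cl)cc1` gives 5000 nM, a step of a 1.7-fold lower number from compound 1 to compound 3 (0.22 log units; within the scatter). Compound 4 `Cc1ccc(N(C)Cc2nc3cc(C(F)(F)F)ccc3nc2-c2ccccc2)cc1` differs from compound 3 by methyl in place of trifluoromethoxy on an aromatic carbon. The measured steps that bear on this change all sit at the same aromatic carbon and are all small: a 1.7-fold lower number from compound 1 to compound 2 (0.22 log units; within the scatter), a 1.7-fold lower number from compound 1 to compound 3 (0.22 log units; within the scatter) and no change at the digits printed from compound 2 to compound 3 (within the scatter). Three exchanges there have left the inhibition constant within the scatter, so no step beyond the scatter is expected in this assay, and the expected step is a 1.2-fold higher number from compound 3 to compound 4 (0.07 log units; within the scatter). Compound 4 is therefore estimated at 3500 nM, with a range from 1500 nM to 8000 nM.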

Compound 4, inhibition constant: 11000 nM
Compound 4: middle estimate off by 3.1-fold (0.50 log units), on the low side; the measured number lies above the stated range.
By their numbers in this assay, from the lowest: compounds 2, 3 and 1 (each within the scatter of the next); then compound 4.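

Among the compounds shown here, the exchange to methyl is the first at this aromatic carbon to go beyond the scatter in this assay, and it does so from all three earlier compounds (a 3.7-fold higher number from compound 3 to compound 4 (0.56 log units; beyond the scatter); a 3.7-fold higher number from compound 2 to compound 4 (0.56 log units; beyond the scatter); a 2.2-fold higher number from compound 1 to compound 4 (0.34 log units; beyond the scatter)). The position therefore does respond to its substituent: trifluoromethoxy, methoxy and chloro stay within the scatter of one another, while methyl stands apart with a higher number. No measurement shown accounts for this difference. As far as these compounds go, it remains open whether an amine or a carboxylic acid at this carbon would group with methyl or with the other three, and whether a longer chain such as ethyl would behave like methyl.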